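Nitro to Amino on Two Related Cores

This account rests on a few compounds, and the source may have more. Where it says the series, first, only, none or still open, it means among the compounds named here.

Compound 1 `COc1ccc(-n2ccnc2-c2cc(OC)c(OC)c(OC)c2)cc1[N+](=O)[O-]` and compound 2 `COc1ccc(-n2ccnc2-c2cc(OC)c(OC)c(OC)c2)cc1N` share one core. In a functional assay on T47D cells (Homo sapiens) for antiproliferative activity, read by MTT assay, with a stated time of 72 h (on this read-out higher numbers stand for weaker inhibition and lower numbers for stronger inhibition), compound 1 gives 10000 nM, while compound 2 gives 500 nM. The change between them is amino in place of nitro on an aromatic carbon, and it produced a 20-fold lower number from compound 1 to compound 2 (1.30 log units; beyond the scatter).

Compound 3 `COc1ccc(C(=O)Oc2cc(OC)c(OC)c(OC)c2)cc1[N+](=O)[O-]` rests on a different core; the difference between the two cores is not broken down here. In this assay compound 3 gives 29600 nM, the highest of the three measured values, and the gap to compound 1 and to compound 2 is visible in their values. Compound 4 `COc1ccc(C(=O)Oc2cc(OC)c(OC)c(OC)c2)cc1N` has not yet been measured. It differs from compound 3 by amino in place of nitro on an aromatic carbon, the same change as that from compound 1 to compound 2, at a place described in the same words.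

Because the same change gave a 20-fold lower number from compound 1 to compound 2 (1.30 log units; beyond the scatter), a step of similar size is expected in this assay, namely a 15-fold lower number from compound 3 to compound 4 (1.17 log units; beyond the scatter). This rests on a single measured pair on another core, so the range is kept wide. Compound 4 is therefore estimated at about 2000 nM, expected between 500 nM and 10000 nM.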

Compound 4, half-maximal inhibitory concentration: > 100000 nM
Compound 4 gave a limit, no number; the forecaster's own chance of this, stated with the estimate: 10%; middle value at least 50-fold (1.69 log units) from the limit.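

In this assay compound 4 gives > 100000 nM, which is a limit of the assay and not a number. Amino in place of nitro on an aromatic carbon therefore did not carry over from the core of compound 1 to the core of compound 3: the direction reversed, with an at least 3.3-fold higher number from compound 3 to compound 4 (0.52 log units; beyond the scatter), and the two steps differ: the same change on two cores in this assay, a 20-fold lower number (1.30 log units; beyond the scatter) from compound 1 to compound 2 and an at least 3.3-fold higher number (0.52 log units; beyond the scatter) from compound 3 to compound 4, at least 67-fold (1.82 log units) apart, beyond the scatter of two such steps. This shows that the step measured on one core could not be transferred to the other in this series, but it does not show why the two cores part ways, nor how large the step on the second core really is, as only its lower bound can be read from: the limit of > 100000 nM in this assay, at which 1 of the 4 values shown sits.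

The compounds shown offer just one nitro and amino pair on each core, which leaves open whether the reversal is particular to these two groups. Going by these compounds, it also remains open how a hydroxyl group or an acetylamino group at the same aromatic carbon would behave on either core in this assay.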